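The source may report more compounds than this note shows. Statements on the series, on what has been measured and on what is new or still open speak of the compounds shown alone.

Measured so far:
compound 1 `O=C(O)CCC(=O)/C=C/c1cn(-c2ccccc2)nc1-c1ccccc1`, 23.5%
compound 2 `O=C(O)CCC(=O)/C=C/c1cn(-c2ccccc2)nc1-c1ccc(Cl)cc1`, 8.64%

In a functional assay on the whole organism (strain albino) for inhibition, with Rattus norvegicus as the target, read by paw edema, with stated times of 30 min and 4 h, at a dose of 50 mg/kg by the oral route (on this read-out lower numbers stand for less inhibition and higher numbers for more inhibition at the one dose given (going by the name of the read-out)), compound 2 stands lowest of the two numbers shown. Its nearest neighbour is compound 1, and the two differ by a number 14.9 percentage points lower from compound 1 to compound 2 (beyond the scatter), a step that carries chloro in place of hydrogen on an aromatic carbon and lies beyond the scatter.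

Compound 3 `Cc1ccc(-c2nn(-c3ccccc3)cc2/C=C/C(=O)CCC(=O)O)cc1` is the next member of the series. It differs from compound 2 in one place: methyl in place of chloro on an aromatic carbon.

Among the measured compounds shown here, only one measured step touches this position, a number 14.9 percentage points lower from compound 1 to compound 2 (beyond the scatter), and it compares chloro with hydrogen, not with methyl. For the measured compounds named here, no measured step puts methyl on this carbon, so the direction of the change from compound 2 to compound 3 is not covered by the numbers in hand. Given that the one known change at this position, compound 1 to compound 2, moved the read-out by a number 14.9 percentage points lower from compound 1 to compound 2 (beyond the scatter), a change of comparable size in either direction cannot be excluded, but nothing in the data points a way. The expected step is a number 6.4 percentage points higher from compound 2 to compound 3 (within the scatter), which is not beyond the scatter. For compound 3 the estimate in this assay is 15%, with a range from 2% to 30%.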

Compound 3, a percentage reported as inhibition, in the whole organism at one dose (the size of the read-out at that dose, not a potency): 13%
For compound 3 the middle estimate is 2 percentage points above the measured one; measured number inside the range.
By their numbers in this assay, from the lowest: compounds 2 and 3 (each within the scatter of the next); then compound 1.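

Notes on the substituent on the aromatic carbon para to a large group, in this assay: going from 4-chlorophenyl to 4-methylphenyl gives a number 4.4 percentage points higher from compound 2 to compound 3 (within the scatter), so chloro and methyl cannot be told apart at this position on this read-out. The other new step, a number 10.5 percentage points lower from compound 1 to compound 3 (beyond the scatter), sits beside the earlier a number 14.9 percentage points lower from compound 1 to compound 2 (beyond the scatter), which means that the loss relative to the unsubstituted phenyl of compound 1 no longer rests on chloro alone: both substituents shown here stand beyond the scatter from hydrogen, with no exception among these three compounds. Nothing in hand gives a reason for this shared loss.

Still open, from the compounds shown here alone, is whether the loss extends to substituents of another kind on this carbon, such as a methoxy group, an amine or a longer alkyl chain, or whether any of these would return the read-out to the level of compound 1. Going by these compounds, with a single oral dose and a single read-out, it also remains open whether the separation between hydrogen and the two substituents would hold at other doses.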